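Methoxyphenyl isomers and solubility across two cores

This account rests on a few compounds, and the source may have more. Where it says the series, first, only, none or still open, it means among the compounds named here.

Compound 1 `COC(=O)CCc1ccc(OCc2oc(-c3ccccc3OC)nc2C)cc1` and compound 2 `COC(=O)CCc1ccc(OCc2oc(-c3cccc(OC)c3)nc2C)cc1` share one core and differ only in the aryl group attached to the five-membered ring. In a physicochemical assay for solubility, tested at 500 uM (on this read-out lower numbers stand for lower solubility and higher numbers for higher solubility), compound 1 gives 62600 nM, and in the same assay compound 2 gives 38200 nM. The change between them, (3-methoxyphenyl in place of 2-methoxyphenyl on an aromatic carbon), produced a step of a 1.6-fold lower number from compound 1 to compound 2 (0.21 log units; within the scatter), so the two numbers cannot be told apart.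

Compound 3 `COc1ccccc1-c1nc(C)c(COc2ccccc2C(=O)O)o1` carries the same 2-methoxyphenyl group on a different core; the difference between the two cores is not broken down here. In this assay compound 3 gives 402000 nM, the highest of the three numbers, lying beyond the scatter from both compound 1 and compound 2. Its number also sits close to the concentration at which the assay is run.

Compound 4 `COc1cccc(-c2nc(C)c(COc3ccccc3C(=O)O)o2)c1` has not yet been measured. It stands to compound 3 as compound 2 stands to compound 1: 3-methoxyphenyl in place of 2-methoxyphenyl on an aromatic carbon. The surroundings of the place are described in the same words for both pairs, so this is the same change carried over to the other core.

Within the data shown here, only one prior instance of the change exists, and it stayed within the scatter, so little movement is expected. Compound 3 already lies near the tested concentration, and a result reported only as a limit is possible. The step from compound 3 to compound 4 is expected to be a 1.5-fold lower number from compound 3 to compound 4 (0.19 log units; within the scatter), resting on a 1.6-fold lower number from compound 1 to compound 2 (0.21 log units; within the scatter). Compound 4 is thus expected to give about 260000 nM in this assay, with a likely range from 130000 nM to 500000 nM.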

Compound 4, solubility: 264000 nM
For compound 4 the middle estimate is 1.0-fold (0.01 log units) below the measured one, within the range that was stated.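

In this assay, 3-methoxyphenyl in place of 2-methoxyphenyl on an aromatic carbon gives a 1.5-fold lower number from compound 3 to compound 4 (0.18 log units; within the scatter) on the core bearing the carboxylic acid, and gives a 1.6-fold lower number from compound 1 to compound 2 (0.21 log units; within the scatter) on the core bearing the methyl ester, so the two isomers cannot be told apart on either core. Across these two pairs, then, the change carries from one core to the other without a step beyond the scatter, but two pairs do not show that it would stay within the scatter on any further core in the series, and steps this small cannot establish a shared effect of the change. Nothing measured here bears on why the isomers behave alike on these two cores.

The compounds shown also leave open whether the same result holds when the methoxy group on the aryl ring gives way to another group, such as an amine or a chlorine atom. As far as these compounds go, it also remains open how a longer chain or an amide at the acid end of the core would read in this assay and whether the isomer pair would still be indistinguishable there.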